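Methyl for Methoxy on the Benzyl Ether of Compound 3

A few compounds are considered here, and "the series" means these few. Any claim that something is new, unique, unknown or untested is made for them only; others in the source may bear on it.

Compound 3 `COc1cccc(COc2ccc3c(Cn4ccnc4)cc(=O)oc3c2)c1` gives 127 nM in an assay on V79MZh11B2 cells for inhibition of cytochrome P450 11B2, mitochondrial (Homo sapiens), read by HPLC, with a stated time of 25 min (on this read-out lower numbers stand for stronger inhibition and higher numbers for weaker inhibition), the lowest of the three numbers recorded, though its gaps to compound 1 `O=c1cc(Cn2ccnc2)c2ccc(OCc3cccc(C(F)(F)F)c3)cc2o1` with 150 nM and to compound 2 `O=c1cc(Cn2ccnc2)c2ccc(OCc3cc(F)cc(F)c3)cc2o1` with 200 nM both lie within the scatter. Compound 4 `Cc1cccc(COc2ccc3c(Cn4ccnc4)cc(=O)oc3c2)c1` differs from compound 3 by methyl in place of methoxy on an aromatic carbon. Within the data shown here, the steps that bear on this change are a 1.2-fold lower number from compound 1 to compound 3 (0.07 log units; within the scatter) and a 1.6-fold lower number from compound 2 to compound 3 (0.20 log units; within the scatter); neither exchange of the group on this ring moved the number beyond the scatter. A methyl in place of the methoxy is therefore expected to give no step beyond the scatter in this assay, namely a 1.1-fold higher number from compound 3 to compound 4 (0.03 log units; within the scatter). Compound 4 is accordingly estimated at 135 nM, within a range from 60 nM to 300 nM.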

Compound 4, half-maximal inhibitory concentration: 250 nM
Compound 4: middle estimate off by 1.9-fold (0.27 log units), on the low side; the measured number falls inside the stated range.
By their numbers in this assay, from the lowest: compounds 3, 1, 2 and 4 (each within the scatter of the next).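

In this assay the 3-methylbenzyl group of compound 4 stays within the scatter of all three earlier compounds, with a 2.0-fold higher number from compound 3 to compound 4 (0.29 log units; within the scatter) as well as a 1.7-fold higher number from compound 1 to compound 4 (0.22 log units; within the scatter) and a 1.3-fold higher number from compound 2 to compound 4 (0.10 log units; within the scatter). Methyl on this aromatic carbon thus joins methoxy, trifluoromethyl and the 3,5-difluoro pattern, and no step among these compounds leaves the scatter. Nothing available explains these steps. Going by these compounds, whether an amine or a carboxylic acid at this place would give a step beyond the scatter remains open.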